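A few compounds are considered here, and "the series" means these few. Any claim that something is new, unique, unknown or untested is made for them only; others in the source may bear on it.

Measured compounds and their numbers in an assay on HL-60 cells for agonist activity at vitamin D3 receptor (Homo sapiens), read by microscopy, with a stated time of 96 h; a higher number here means that more compound is needed for the effect, a lower number that less compound is needed:
compound 1, `CCn1c(C(=O)NCC(OC)OC)ccc1C(CC)(CC)c1ccc(OCC(O)C(C)(C)C)c(C)c1`: 150 nM
compound 2, `CC[C@@H](C)[C@H](NC(=O)c1ccc(C(CC)(CC)c2ccc(OCC(O)C(C)(C)C)c(C)c2)n1CC)C(=O)O`: 2.3 nM

Going by the values given here, compound 2 stands lowest of the two numbers so far in this assay; the only neighbour is compound 1, and the gap between them, a 65-fold lower number from compound 1 to compound 2 (1.81 log units; beyond the scatter), is the single step recorded. That step, in which the 1-carboxy-2-methylbutyl group replaces the 2,2-dimethoxyethyl group on the amide-type nitrogen, is large and beyond the scatter.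

Compound 3, `CCOC(=O)c1ccc(OC(=O)c2ccc(C(CC)(CC)c3ccc(OCC(O)C(C)(C)C)c(C)c3)n2CC)cc1`, differs from compound 2 by 4-(ethoxycarbonyl)phenoxy in place of (1-carboxy-2-methylbutyl)amino on a carbonyl carbon. The step from compound 1 to compound 2 bears on this change in reverse: the group whose arrival brought the large gain leaves again, and what enters carries no carboxylic acid and no hydrogen-bond donor, and the amide nitrogen itself is gone. Among the compounds with values here, no measured pair covers an ester at this carbonyl, so the size is uncertain, but the direction expected in this assay is a higher number, of roughly the magnitude seen in a 65-fold lower number from compound 1 to compound 2 (1.81 log units; beyond the scatter). Compound 3 is therefore estimated at 200 nM, within 40 nM to 1500 nM, an expected step of an 87-fold higher number from compound 2 to compound 3 (1.94 log units; beyond the scatter).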

Compound 3, half-maximal effective concentration: > 50000 nM
Compound 3: no number, only a limit; the forecaster's own chance of this, stated with the estimate: 10%; middle value at least 250-fold (2.39 log units) from the limit.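

Compound 3 gives no number, only a limit, in this assay: the limit of > 50000 nM in this assay, at which 1 of the 3 values shown sits. Putting 4-(ethoxycarbonyl)phenoxy on this carbonyl carbon gives an at least 21000-fold higher number from compound 2 to compound 3 (4.33 log units; beyond the scatter) where (1-carboxy-2-methylbutyl)amino leaves, and an at least 330-fold higher number from compound 1 to compound 3 (2.52 log units; beyond the scatter) where (2,2-dimethoxyethyl)amino leaves. The second step adds what the earlier pair could not show: compound 1 also has no carboxylic acid yet still gives 150 nM, so the absence of that acid does not alone account for the result, and this position does not merely separate better amides from poorer ones.

The change replaces the linking nitrogen and the whole substituent at once, so these compounds cannot say whether the loss follows from the ester link, the aromatic ring or the ethoxycarbonyl group. An anilide carrying the same 4-ethoxycarbonyl group would test the link with the ring kept, while a plain methyl ester on this carbonyl would test the link without the ring.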